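A few compounds are considered here, and "the series" means these few. Any claim that something is new, unique, unknown or untested is made for them only; others in the source may bear on it.

The measured compounds:
Compound 1, `Cc1[nH]cnc1[C@@H]1[C@@H](c2cc(Cl)cc(Cl)c2)C1(C)C`, 950 nM
Compound 2, `CC1(C)[C@H](c2cnc(N)s2)[C@H]1c1cccc2c1CCO2`, > 30000 nM (a limit of the assay)
Compound 3, `CC1(C)[C@H](c2cc(Cl)cc(Cl)c2)[C@H]1c1cnc(N)s1`, > 30000 nM (a limit of the assay)

In a functional assay on AP1 cells for inhibition of sodium/hydrogen exchanger 1 (Homo sapiens) (on this read-out higher numbers stand for weaker inhibition and lower numbers for stronger inhibition), compound 1 gives 950 nM. Compound 3 reaches only a limit of the assay, > 30000 nM. Compound 2 likewise reaches only a limit, > 30000 nM. The change 5-methyl-1H-imidazol-4-yl in place of 2-amino-1,3-thiazol-5-yl on a saturated ring carbon brought an at least 31-fold lower number from compound 3 to compound 1 (1.49 log units; beyond the scatter); the size of that step rests on (the limit of > 30000 nM in this assay, at which 2 of the 3 values shown sit). Compound 4, `Cc1[nH]cnc1[C@@H]1[C@@H](c2cccc3c2CCO3)C1(C)C`, carries the same kind of change from compound 2: 5-methyl-1H-imidazol-4-yl in place of 2-amino-1,3-thiazol-5-yl on a saturated ring carbon. How the cores of compound 2 and compound 3 differ is not broken down here; around the place, the ring atom bears a group of 9 heavy atoms in compound 2 and a group of 8 heavy atoms in compound 3, so the change is the same kind, not the same. Compound 2 stands only at a limit. Compound 4 is expected to make an at least 6.0-fold lower number from compound 2 to compound 4 (0.77 log units; beyond the scatter), resting on an at least 31-fold lower number from compound 3 to compound 1 (1.49 log units; beyond the scatter). Compound 4 is estimated at 5000 nM, between 1000 nM and 30000 nM.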

Compound 4, half-maximal inhibitory concentration: 11000 nM
Beside the measured number, compound 4's estimate is 2.2-fold (0.34 log units) below it, within the range that was stated.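

In this assay, 5-methyl-1H-imidazol-4-yl in place of 2-amino-1,3-thiazol-5-yl again gives a lower number on the core of compound 2, with an at least 2.7-fold lower number from compound 2 to compound 4 (0.43 log units; beyond the scatter). The direction of the change therefore carries over from one core to the other, but the two sizes cannot be set against each other: the same change on two cores in this assay, an at least 31-fold lower number (1.49 log units; beyond the scatter) from compound 3 to compound 1 and an at least 2.7-fold lower number (0.43 log units; beyond the scatter) from compound 2 to compound 4; the limit leaves it open whether they differ. Each step starts from a limit of the assay, so each gives only a minimum size, not a true one: the limit of > 30000 nM in this assay, at which 2 of the 4 values shown sit.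

On these data alone, how an unsubstituted 1H-imidazol-4-yl or a pyridin-4-yl group would read on the same saturated ring carbon remains open. Also open, as far as these compounds go, is what the change would do on a core where the 2-amino-1,3-thiazol-5-yl compound gives a number rather than a limit.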